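Thiazolylidene-imine series: ester in place of phenyl

The source may hold more compounds than are shown below. What is called first, only, known or untested is meant among the compounds shown, and "the series" means these compounds.

Compound 1 `Cc1c(-c2csc(/N=c3\sc(-c4ccccc4)nn3-c3ccccc3)n2)c(=O)n(-c2ccccc2)n1C` is measured in a functional assay on MCF7 cells (Homo sapiens) for cytotoxicity, read by sulforhodamine B assay, with a stated time of 72 h (on this read-out higher numbers stand for weaker inhibition and lower numbers for stronger inhibition), and gives only a limit there, > 100000 nM. Two analogues differ elsewhere on the shared core. Compound 2 `COc1ccc(-n2nc(C(C)=O)s/c2=N\c2nc(-c3c(C)n(C)n(-c4ccccc4)c3=O)cs2)cc1` gives 64500 nM in this assay. Compound 3 `CC(=O)c1nn(-c2ccc([N+](=O)[O-])cc2)/c(=N/c2nc(-c3c(C)n(C)n(-c4ccccc4)c3=O)cs2)s1` gives a limit in this assay, > 100000 nM. Among the measured compounds shown here, the only single-point step among the measured compounds is an at least 1.5-fold higher number from compound 2 to compound 3 (0.19 log units; that floor lies within the scatter), and it concerns a substituent far from the position considered here, so it does not bear on the present change. For the measured compounds named here, compound 1 therefore stands at the limit of > 100000 nM in this assay, at which 2 of the 3 values shown sit, with no measured step starting from it.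

Compound 4 `CCOC(=O)c1nn(-c2ccccc2)/c(=N/c2nc(-c3c(C)n(C)n(-c4ccccc4)c3=O)cs2)s1` differs from compound 1 by ethoxycarbonyl in place of phenyl on an aromatic carbon. Going by the values given here, no measured step tells what ethoxycarbonyl in place of phenyl on that aromatic carbon does. What the values show is that compound 2, which carries an acetyl group at the same position, gives a number in this assay, whereas compound 1 gives a limit. The expected step is an at least 1.2-fold lower number from compound 1 to compound 4 (0.09 log units; that floor lies within the scatter), toward a somewhat lower number, but it may not exceed the scatter. For compound 4 the estimate in this assay is 80000 nM, within a range from 30000 nM to 200000 nM, and a limit rather than a number remains about as likely as not.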

Compound 4, half-maximal inhibitory concentration: > 100000 nM
Compound 4 ended at the assay's limit; the forecaster's own chance of this, stated with the estimate: 50%; at least 1.2-fold (0.09 log units) between middle value and limit.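

Among the compounds shown here, compound 4 also ends at a limit in this assay, as compound 1 does, so no step between the two can be read: the limit of > 100000 nM in this assay, at which 3 of the 4 values shown sit. The compounds shown leave open whether ethoxycarbonyl in place of phenyl on that aromatic carbon changes the number at all, and compound 2 remains the only one with a number rather than a limit.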